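Compound 3 Expected to Track Compounds 1 and 2

This account rests on a few compounds, and the source may have more. Where it says the series, first, only, none or still open, it means among the compounds named here.

Two measured compounds anchor this account. Compound 1 `CCc1ccc2nc(C(=O)Nc3c(F)cc(-c4cccc(F)c4)cc3F)c(C)c(O)c2c1` and compound 2 `Cc1ccc2nc(C(=O)Nc3c(F)cc(-c4cccc(F)c4)cc3F)c(C)c(C(=O)O)c2c1` were both tested in a functional assay on A-375 cells (Homo sapiens) for antiproliferative activity, read by MTT assay, with a stated time of 24 h, tested at 0.02 ug/mL; a lower number here means a weaker effect, a higher number a stronger effect of the compound at the concentration tested. In this assay compound 1 gives -0.12%. Compound 2 gives 0.02% in this assay, which is the higher of the two numbers, though the gap to compound 1 lies within the scatter of repeated measurements, so no order between them can be drawn. Both read-outs amount to essentially no inhibition at the concentration tested.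

Compound 3 `CCc1ccc2nc(C(=O)Nc3c(F)cc(-c4cccc(F)c4)cc3F)c(C)c(C(=O)O)c2c1` has not yet been measured. It differs from compound 2 in one place: methyl in place of hydrogen on a saturated chain carbon bound to an aromatic carbon. Among the measured compounds shown here, no pair of measured compounds shows this same change, so its effect cannot be read from the numbers at hand. Because compound 2 gives 0.02% and compound 1 gives -0.12%, both amounting to essentially no inhibition at the concentration tested, the step from compound 2 to compound 3 in this assay is expected to be a number 0 percentage points lower from compound 2 to compound 3 (within the scatter), which is none beyond the scatter. Compound 3 is therefore estimated to give 0% in this assay, with a range from -10% to 10%.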

Compound 3, a percentage reported as inhibition, at one concentration (the size of the read-out at that concentration, not a potency): -0.12%
The estimate for compound 3 lay 0.1 percentage points above the measured number; the measured number falls inside the stated range.
By their numbers in this assay, from the lowest: compounds 1, 3 and 2 (each within the scatter of the next).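

Among the compounds shown here, compound 3 gives the first reading of a single change at this position: methyl in place of hydrogen on a saturated chain carbon bound to an aromatic carbon, the change from methyl to ethyl, comes with a number 0.1 percentage points lower from compound 2 to compound 3 (within the scatter) in this assay at the concentration tested. For the compounds shown here, it also gives the first reading of a second place, where carboxy in place of hydroxy on an aromatic carbon comes with no change at the digits printed from compound 1 to compound 3 (within the scatter) in the same read-out. Neither step leaves the scatter, and all three compounds stay at essentially no inhibition, so at this one concentration neither change separates these compounds. No independent measurement bears on this result.

What the compounds shown leave open is whether a longer chain such as propyl on the saturated carbon, or an amine on the aromatic carbon that carries the hydroxy or carboxy group, would bring the read-out beyond the scatter. From the compounds shown here alone, it also remains open whether the methyl to ethyl change and the swap of hydroxy for carboxy would stay this flat at a higher concentration, where inhibition could be seen at all.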